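The compounds below may be only part of what the source reports. "The series", "measured", "known", "first", "only" and "open" are said of these compounds alone.

Measured compounds in an assay on HEK293 cells for binding affinity to sodium channel protein type 4 subunit alpha (Homo sapiens); a lower number here means a stronger inhibitor, a higher number a weaker inhibitor:
- compound 1, `Cn1ccc(-c2ccc(Oc3ccc(F)cc3)cc2)n1`, gives 690 nM
- compound 2, `NC(=O)n1ccc(-c2ccc(Oc3ccc(F)cc3)cc2)n1`, gives 31 nM
- compound 3, `NC(=O)n1ccc(-c2ccc(Oc3ccccc3)cc2)n1`, gives 35 nM

Among these three, compound 2 has the lowest number; compound 3 sits within the usual scatter of it, and only compound 1 lies clearly apart. The large step came with a 22-fold lower number from compound 1 to compound 2 (1.35 log units; beyond the scatter), while a 1.1-fold higher number from compound 2 to compound 3 (0.05 log units; within the scatter) shows that changing the fluoro on the far ring makes no visible difference.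

Compound 4, `CN(C)C(=O)n1ccc(-c2ccc(Oc3ccc(F)cc3)cc2)n1`, is not yet measured. It differs from compound 2 by dimethylamino in place of amino on a carbonyl carbon. Going by the values given here, no measured step touches this position in the same way; the closest one is the exchange on the aromatic nitrogen that produced a 22-fold lower number from compound 1 to compound 2 (1.35 log units; beyond the scatter), which shows that this end of the molecule matters a great deal in this assay. Because that step a 22-fold lower number from compound 1 to compound 2 (1.35 log units; beyond the scatter) was so large, compound 4 is expected to land somewhere between compound 1 and compound 2 rather than beside compound 2, so a moderate rise in the number is expected, a 4.8-fold higher number from compound 2 to compound 4 (0.68 log units; beyond the scatter). Compound 4 is therefore estimated at 150 nM, with a range from 40 nM to 600 nM.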

Compound 4, inhibition constant: 340 nM
Compound 4: middle estimate off by 2.3-fold (0.36 log units), on the low side, within the range that was stated.
By their numbers in this assay, from the lowest: compounds 2 and 3 (each within the scatter of the next); then compound 4; then compound 1.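

In this assay, the carbonyl alone does not secure the gain seen earlier: dimethylamino in place of amino on the carbonyl carbon gives an 11-fold higher number from compound 2 to compound 4 (1.04 log units; beyond the scatter) and leaves only a modest edge over the methyl compound, with a 2.0-fold lower number from compound 1 to compound 4 (0.31 log units; beyond the scatter) remaining. The earlier compounds shown here changed the whole group on the aromatic nitrogen, whereas this result shows that most of the gain depends on what is attached to the carbonyl carbon. Nothing shown here gives a reason for this loss.

The change takes away the hydrogen-bond donor and adds carbon at the same time, and the compounds shown do not separate these two differences. Methylamino, which keeps a hydrogen on the nitrogen, would help to separate them, while the effect of a longer chain such as diethylamino also remains open.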